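The source may hold more compounds than are shown below. What is called first, only, known or untested is meant among the compounds shown, and "the series" means these compounds.

Three compounds were measured in a functional assay on A2780 cells (Homo sapiens) for inhibition; a lower number here means a stronger inhibitor, a higher number a weaker inhibitor:

Compound 1 `CCNC(=O)c1noc(-c2cc(C(C)C)c(O)cc2O)c1-c1cc(CNC(C)C)no1`: 38 nM
Compound 2 `CCNC(=O)c1noc(-c2cc(C(C)C)c(O)cc2O)c1-c1cc(C(N)=O)no1`: 15 nM
Compound 3 `CCNC(=O)c1noc(-c2cc(C(C)C)c(O)cc2O)c1-c1cc(C(=O)NC)no1`: 100 nM

Compound 3 gives the highest number of the three; the steps leading to it are a 2.6-fold higher number from compound 1 to compound 3 (0.42 log units; beyond the scatter) and a 6.7-fold higher number from compound 2 to compound 3 (0.82 log units; beyond the scatter). Compound 4 `CCNC(=O)c1noc(-c2cc(C(C)C)c(O)cc2O)c1-c1cnn(CC)c1` differs from compound 3 by 1-ethyl-1H-pyrazol-4-yl in place of 3-(methylcarbamoyl)-1,2-oxazol-5-yl on an aromatic carbon. The measured steps each alter a group on the ring that is now exchanged, or the hydrogen on its amide-type nitrogen; none replaces the ring itself, so they bear only loosely on this change. They show that changes at this position move the number modestly in either direction: a 2.5-fold lower number from compound 1 to compound 2 (0.40 log units; beyond the scatter), a 6.7-fold higher number from compound 2 to compound 3 (0.82 log units; beyond the scatter). A modest step of uncertain direction is therefore expected, a 1.7-fold lower number from compound 3 to compound 4 (0.22 log units; within the scatter). Compound 4 is estimated at 60 nM, between 15 nM and 250 nM.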

Compound 4, half-maximal inhibitory concentration: 30 nM
Compound 4: middle estimate off by 2.0-fold (0.30 log units), on the high side; the range from low to high includes it.
By their numbers in this assay, from the lowest: compounds 2, 4 and 1 (each within the scatter of the next, the first and the last beyond it); then compound 3.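

Exchanging the whole ring at this position, not only a group on it, gives a 3.3-fold lower number from compound 3 to compound 4 (0.52 log units; beyond the scatter) in this assay and so recovers much of what compound 3 loses. The 1-ethyl-1H-pyrazol-4-yl group has no hydrogen-bond donor, yet a 2.0-fold higher number from compound 2 to compound 4 (0.30 log units; within the scatter) and a 1.3-fold lower number from compound 1 to compound 4 (0.10 log units; within the scatter) both stay within the scatter, so this position accepts more than the 1,2-oxazol-5-yl groups. No available evidence explains these steps.

On these data alone, it remains open whether the ring or its ethyl group accounts for the step from compound 3. A methyl, a propyl chain or an amine in place of that ethyl could help to separate the two.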